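Benzyloxy to methoxymethoxy on the shared core

The source may report more compounds than this note shows. Statements on the series, on what has been measured and on what is new or still open speak of the compounds shown alone.

Among the measured compounds shown here, in a functional assay on RAW264.7 cells (Mus musculus) for inhibition, read by Griess assay, with stated times of 1 h and 24 h (on this read-out higher numbers stand for weaker inhibition and lower numbers for stronger inhibition), compound 3 `O=C1CC(c2ccccc2OCc2ccccc2)Oc2ccccc21` gives a value of 18900 nM and stands at the low end of the numbers so far. Compound 1 `CC(C)c1ccc(COc2ccccc2C2CC(=O)c3ccccc3O2)cc1` gives 27100 nM and lies within the scatter of compound 3. Compound 2 `CCCCOc1ccccc1C1CC(=O)c2ccccc2O1` gives 48700 nM and lies beyond the scatter of compound 3.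

The next compound is compound 4 `COCOc1ccccc1C1CC(=O)c2ccccc2O1`, with methoxy in place of phenyl on a saturated chain carbon bound to an oxygen on an aromatic ring. The closest measured precedent is the change from propyl to phenyl at the same place (a 2.6-fold lower number from compound 2 to compound 3 (0.41 log units; beyond the scatter)), a modest step. Its reverse suggests a higher number once phenyl leaves. The step between compound 1 and compound 2 (a 1.8-fold higher number from compound 1 to compound 2 (0.25 log units; within the scatter)) points the same way but stays within the scatter. For the measured compounds named here, no measured compound carries an oxygen in this chain, so the uncertainty is wide.

A modest rise is expected (a 2.4-fold higher number from compound 3 to compound 4 (0.38 log units; beyond the scatter)). The estimate for compound 4 is 45000 nM, with an expected range from 18000 nM to 100000 nM in this read-out.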

Compound 4, half-maximal inhibitory concentration: 32600 nM
Compound 4: the middle estimate sits 1.4-fold (0.14 log units) above what was measured; measured number inside the range.
By their numbers in this assay, from the lowest: compounds 3, 1, 4 and 2 (each within the scatter of the next, the first and the last beyond it).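

In this assay, methoxy at this place, on a saturated chain carbon bound to an oxygen on an aromatic ring, stays within the scatter of all three earlier groups: phenyl (a 1.7-fold higher number from compound 3 to compound 4 (0.24 log units; within the scatter)), propyl (a 1.5-fold lower number from compound 2 to compound 4 (0.17 log units; within the scatter)) and 4-isopropylphenyl (a 1.2-fold higher number from compound 1 to compound 4 (0.08 log units; within the scatter)). Among the compounds shown here, compound 4 is thus the first compound with an oxygen in this chain, and it shows that neither that oxygen nor the loss of the aromatic ring gives a step beyond the scatter from any earlier compound, although compound 2 and compound 3 do differ beyond it. No measurement shown accounts for these small steps.

Open, going by these compounds, is whether an amine or a carboxylic acid at this place would give a step beyond the scatter from compound 3. Also open, on these data alone, is whether a longer chain carrying several oxygens would stay within it.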